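The source may report more compounds than this note shows. Statements on the series, on what has been measured and on what is new or still open speak of the compounds shown alone.

Measured compounds:
- compound 1, `Cc1c(CO)cccc1NS(=O)(=O)c1ccc(-c2ccc(Br)cc2)cc1`: 12 ug/mL
- compound 2, `Cc1ccc(CO)cc1NS(=O)(=O)c1ccc(-c2ccc(Br)cc2)cc1`: 47 ug/mL
- compound 3, `O=S(=O)(Nc1cccc(CO)c1Cl)c1ccc(-c2ccc(Br)cc2)cc1`: 14 ug/mL

All three numbers come from a physicochemical assay for solubility, read by HPLC, in simulated intestinal fluid, measured as thermodynamic solubility, with a stated time of 24 h; a higher number here means a more soluble compound, a lower number a less soluble compound. The difference between the core of compound 1 and the core of compound 2 is not broken down here. Within the core of compound 1, the change chloro in place of methyl on an aromatic carbon gave a 1.2-fold higher number from compound 1 to compound 3 (0.07 log units; within the scatter). Compound 2 stands apart from compound 1 and compound 3 beyond the scatter.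

Compound 4, `O=S(=O)(Nc1cc(CO)ccc1Cl)c1ccc(-c2ccc(Br)cc2)cc1`, is not yet measured in this assay. It carries the change (chloro in place of methyl on an aromatic carbon), the same kind of change as in compound 3, though there the place was ortho to a hydroxymethyl group, whereas here it is para to a hydroxymethyl group. Because the first step was a 1.2-fold higher number from compound 1 to compound 3 (0.07 log units; within the scatter), the step from compound 2 is expected to be about a 1.1-fold higher number from compound 2 to compound 4 (0.03 log units; within the scatter). For compound 4 the expected value in this assay is 50 ug/mL, between 22 ug/mL and 110 ug/mL.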

Compound 4, solubility: 11 ug/mL
Beside the measured number, compound 4's estimate is 4.5-fold (0.66 log units) above it, outside the stated range (below it).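

In this assay chloro in place of methyl on an aromatic carbon gave a 4.3-fold lower number from compound 2 to compound 4 (0.63 log units; beyond the scatter) in the core of compound 2 but a 1.2-fold higher number from compound 1 to compound 3 (0.07 log units; within the scatter) in the core of compound 1 and so did not carry over from one core to the other at the same size. This rests on a single pair in each core and does not show how the change would behave in any further core. No measurement given here accounts for the difference between these two steps.

Still open, as far as these compounds go, is whether an amine or a carboxylic acid in place of the methyl would also differ between these two cores. Also open, from the compounds shown here alone, is whether a longer chain in place of the hydroxymethyl group would alter the outcome of the chloro change.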